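Isopropyl to phenyl on an oxygen: a step past the limit

A few compounds are considered here, and "the series" means these few. Any claim that something is new, unique, unknown or untested is made for them only; others in the source may bear on it.

Measured in an ADME assay on HepG2 cells (Homo sapiens) for cytotoxicity, read by luminescence, with a stated time of 72 h; on this read-out lower numbers stand for an effect already at smaller amounts and higher numbers for an effect only at larger amounts of compound:
- compound 1 `C=Cc1cccc(-c2[nH]c3cc(OC)ccc3c(=O)c2C(=O)OCC)c1`: > 21500 nM (a limit)
- compound 2 `CCCOc1cccc(-c2[nH]c3cc(OC)ccc3c(=O)c2C(=O)OCC)c1`: > 21500 nM (a limit)
- compound 3 `CCOC(=O)c1c(-c2cccc(OC(C)C)c2)[nH]c2cc(OC)ccc2c1=O`: > 21500 nM (a limit)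

In this assay compound 3 stands at > 21500 nM, which is a limit of the assay and not a number. The other two compounds share it: the limit of > 21500 nM in this assay, at which 3 of the 3 values shown sit. Compound 4 `CCOC(=O)c1c(-c2cccc(Oc3ccccc3)c2)[nH]c2cc(OC)ccc2c1=O` differs from compound 3 in one place: phenyl in place of isopropyl on an oxygen on an aromatic ring. One measured step changes the group on that same oxygen, and it is a step that the two limits leave unreadable from compound 2 to compound 3. The other two are a step that the two limits leave unreadable from compound 1 to compound 2 and a step that the two limits leave unreadable from compound 1 to compound 3. None of the three has a readable size, so they point in no direction, and no step beyond the usual scatter is expected. The expected change is a step that the limit leaves unreadable from compound 3 to compound 4. The estimate for compound 4 is 24000 nM, in a range from 12000 nM to 40000 nM.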

Compound 4, half-maximal effective concentration: > 21500 nM
Compound 4 ended at the assay's limit; the forecaster's own chance of this, stated with the estimate: 75%; the middle value does not contradict the limit.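

Compound 4 adds no readable step: its value, like those of compound 1, compound 2 and compound 3, is a limit of the assay, not a number. The compounds shown leave open where in this assay any of them would reach its half-maximal effect.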